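Swapping amino for fluoro on a pendant phenyl ring

This account rests on a few compounds, and the source may have more. Where it says the series, first, only, none or still open, it means among the compounds named here.

Measured in an assay on membranes from brain for binding affinity to adenosine receptor A1 (Rattus norvegicus), read by radioligand binding, tested at 20 uM; a lower number here means less inhibition, a higher number more inhibition at the concentration tested (going by the name of the read-out):
compound 1, `Cn1c(=O)[nH]c2c(cnn2-c2ccc(N)cc2)c1=N`, 0%
compound 2, `Cn1c(=O)[nH]c2c(cnn2-c2ccc(F)cc2)c1=N`, 26%
compound 3, `Cn1c(=O)[nH]c2c(cnn2-c2cccc(N)c2)c1=N`, 0%

Compound 3 stands level with compound 1 in this assay, within the scatter. Compound 2 differs from compound 1 by fluoro in place of amino on an aromatic carbon and gives a number 26 percentage points higher from compound 1 to compound 2 (beyond the scatter). Compound 3 and compound 1 have the same atoms joined differently; that difference between the two cores is not broken down here.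

Compound 4, `Cn1c(=O)[nH]c2c(cnn2-c2cccc(F)c2)c1=N`, differs from compound 3 by fluoro in place of amino on an aromatic carbon. This is the same kind of change as that from compound 1 to compound 2, but the place differs: para to a large group there, meta to a large group here. For the measured compounds named here, since the only measured step of this kind is a number 26 percentage points higher from compound 1 to compound 2 (beyond the scatter), a step of similar size is expected, a number 20 percentage points higher from compound 3 to compound 4 (beyond the scatter). Compound 4 is therefore estimated at 20%, between 0% and 45%.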

Compound 4, a percentage reported as inhibition, at one concentration (the size of the read-out at that concentration, not a potency): 44%
The estimate for compound 4 lay 24 percentage points below the measured number, within the range that was stated.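

Fluoro in place of amino gives a number 44 percentage points higher from compound 3 to compound 4 (beyond the scatter) in this assay and so repeats the direction seen with the first pair. The direction carries over to the second core, but the size does not: the same change on two cores in this assay, a number 26 percentage points higher (beyond the scatter) from compound 1 to compound 2 and a number 44 percentage points higher (beyond the scatter) from compound 3 to compound 4, 18 percentage points apart, beyond the scatter of two such steps

For the compounds shown here, with only two pairs, this does not show why the two sizes differ, or what the same change would give on any further core.

The compounds shown leave open how other groups on the pendant phenyl ring would compare, such as chloro, methoxy or a carboxylic acid. They also leave open whether an ethyl group in place of the methyl on the shared core would alter the size of the step.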